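Swapping methylsulfonyl for nitro on a second core

A few compounds are considered here, and "the series" means these few. Any claim that something is new, unique, unknown or untested is made for them only; others in the source may bear on it.

Measured compounds:
compound 1 `CS(=O)(=O)c1ccc(C(=O)N2CCC(n3cncc3-c3ccc(OS(=O)(=O)c4cccc5cnccc45)cc3)CC2)cc1`, 25 nM
compound 2 `O=C(c1ccc([N+](=O)[O-])cc1)N1CCC(n2cncc2-c2ccc(OS(=O)(=O)c3cccc4cnccc34)cc2)CC1`, 1.49 nM
compound 3 `CNC(=O)c1cccc(S(=O)(=O)Oc2ccc(-c3cncn3C3CCN(C(=O)c4ccc(S(C)(=O)=O)cc4)CC3)cc2)c1`, 202 nM

All three were tested in an assay on HEK293 cells for antagonist activity at P2X purinoceptor 7 (Homo sapiens), read by fluorescence, with a stated time of 2 h; on this read-out higher numbers stand for weaker inhibition and lower numbers for stronger inhibition. Compound 2 differs from compound 1 by nitro in place of methylsulfonyl on an aromatic carbon, and this change gave a 17-fold lower number from compound 1 to compound 2 (1.22 log units; beyond the scatter). Compound 3 carries a different core; it differs from compound 1 by 3-(methylcarbamoyl)phenyl in place of isoquinolin-5-yl on a sulfonyl sulfur, which gave an 8.1-fold higher number from compound 1 to compound 3 (0.91 log units; beyond the scatter), so compound 3 has the highest number of the three.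

Compound 4 `CNC(=O)c1cccc(S(=O)(=O)Oc2ccc(-c3cncn3C3CCN(C(=O)c4ccc([N+](=O)[O-])cc4)CC3)cc2)c1` is not yet measured. It differs from compound 3 by nitro in place of methylsulfonyl on an aromatic carbon, and this is the same change seen from compound 1 to compound 2, at the same place. On that one example, compound 4 is expected to give a lower number than compound 3, with a step of about an 11-fold lower number from compound 3 to compound 4 (1.05 log units; beyond the scatter), since the changed core could alter the size of the effect. The estimate for compound 4 in this assay is 18 nM.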

Compound 4, half-maximal inhibitory concentration: 62 nM
Compound 4: the middle estimate sits 3.4-fold (0.54 log units) below what was measured; the measured number lies above the stated range.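

In this assay, nitro in place of methylsulfonyl lowers the number on the second core as well, with a 3.3-fold lower number from compound 3 to compound 4 (0.51 log units; beyond the scatter), so the direction of the change carries over but its size does not: the same change on two cores in this assay, a 17-fold lower number (1.22 log units; beyond the scatter) from compound 1 to compound 2 and a 3.3-fold lower number (0.51 log units; beyond the scatter) from compound 3 to compound 4, 5.1-fold (0.71 log units) apart, beyond the scatter of two such steps. Seen from the other side, 3-(methylcarbamoyl)phenyl in place of isoquinolin-5-yl gives a 42-fold higher number from compound 2 to compound 4 (1.62 log units; beyond the scatter) when nitro is present, which is the same gap between the same four compounds: the same change on two cores in this assay, an 8.1-fold higher number (0.91 log units; beyond the scatter) from compound 1 to compound 3 and a 42-fold higher number (1.62 log units; beyond the scatter) from compound 2 to compound 4, 5.1-fold (0.71 log units) apart, beyond the scatter of two such steps. The two changes therefore do not add up independently in these four compounds, but this does not show why, or how the nitro step would behave on any further core.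

Still open, on these data alone, is whether another group in the place of methylsulfonyl, such as a nitrile or an amine, would lower the number as nitro does. Also open, as far as these compounds go, is how large the nitro step would be with a different group on the sulfonyl sulfur, such as a plain phenyl.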